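A few compounds are considered here, and "the series" means these few. Any claim that something is new, unique, unknown or untested is made for them only; others in the source may bear on it.

Two compounds of the series are measured in a functional assay on cells (Pituitary gland cell) with growth hormone secretagogue receptor type 1 (Rattus norvegicus) as the target; a lower number here means that less compound is needed, a higher number that more compound is needed for the effect. Compound 1 `CC(C)(CC(=O)N[C@@H]1CCc2ccccc2N(Cc2ccc(-c3ccccc3-c3nn[nH]n3)cc2)C1=O)NCc1ccccc1` gives 65 uM. Compound 2 `CC[C@@H](N)C(=O)N[C@@H]1CCc2ccccc2N(Cc2ccc(-c3ccccc3-c3nn[nH]n3)cc2)C1=O` gives 0.3 uM, the lower of the two numbers. For the measured compounds named here, the only step on record, a 220-fold lower number from compound 1 to compound 2 (2.34 log units; beyond the scatter), is large. Compound 3 `CC(C)(CC(=O)N[C@@H]1CCc2ccccc2N(Cc2ccc(-c3ccccc3-c3nn[nH]n3)cc2)C1=O)NCCO` differs from compound 2 by 2-((2-hydroxyethyl)amino)-2-methylpropyl in place of 1-aminopropyl on a carbonyl carbon. The entering group resembles the 2-(benzylamino)-2-methylpropyl of compound 1 more than the 1-aminopropyl of compound 2, so a large rise is expected for compound 3, roughly reversing a 220-fold lower number from compound 1 to compound 2 (2.34 log units; beyond the scatter) but falling short of it because compound 1 gives 65 uM with a benzyl rather than a hydroxyethyl. The expected step is a 67-fold higher number from compound 2 to compound 3 (1.82 log units; beyond the scatter). The estimate for compound 3 in this assay is 20 uM, within 3 uM to 100 uM.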

Compound 3, concentration for half-maximal effect: 30 uM
For compound 3 the middle estimate is 1.5-fold (0.18 log units) below the measured one; the measured number falls inside the stated range.
By their numbers in this assay, from the lowest: compound 2; then compound 3; then compound 1.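

In this assay there is a 100-fold higher number from compound 2 to compound 3 (2.00 log units; beyond the scatter), so the high number of compound 1 does not depend on its benzyl alone: a 2-((2-hydroxyethyl)amino)-2-methylpropyl on the same carbonyl carbon also gives a large rise. Hydroxymethyl in place of phenyl gives only a 2.2-fold lower number from compound 1 to compound 3 (0.34 log units; beyond the scatter), a modest step beside the large change away from 1-aminopropyl. Nothing on hand accounts for either step.

The 2>3 change alters both the chain and the amine substituent, so their shares remain unseparated. A plain 2-amino-2-methylpropyl on this carbonyl carbon would help divide them.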